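The source may hold more compounds than are shown below. What is called first, only, known or untested is meant among the compounds shown, and "the series" means these compounds.

Measured compounds:
compound 1 `Cc1cc(F)c(S(C)(=O)=O)cc1C(=O)N=C(N)N`, 44 nM
compound 2 `CSc1cc(C)c(C(=O)N=C(N)N)cc1S(C)(=O)=O`, 6 nM

Compound 2 gives the lower of the two numbers in a functional assay for inhibition of sodium/hydrogen exchanger (Oryctolagus cuniculus); on this read-out higher numbers stand for weaker inhibition and lower numbers for stronger inhibition; the step of a 7.3-fold lower number from compound 1 to compound 2 (0.87 log units; beyond the scatter) lies beyond the scatter. Compound 3 `Cc1cc(Sc2ccccc2)c(S(C)(=O)=O)cc1C(=O)N=C(N)N` carries phenyl in place of methyl on a sulfur. Among the compounds with values here, no measured step alters the group on the sulfur itself; the single step known, a 7.3-fold lower number from compound 1 to compound 2 (0.87 log units; beyond the scatter), exchanged the group on the ring carbon and says nothing about growing the sulfur substituent. With no direct guidance, no step beyond the scatter is expected in this assay, direction open. Compound 3 is estimated at 8 nM, range 2 nM to 40 nM. The expected step is a 1.3-fold higher number from compound 2 to compound 3 (0.12 log units; within the scatter).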

Compound 3, half-maximal inhibitory concentration: 14 nM
The estimate for compound 3 lay 1.8-fold (0.24 log units) below the measured number, within the range that was stated.
By their numbers in this assay, from the lowest: compound 2; then compound 3; then compound 1.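

In this assay, the aromatic carbon that held fluoro in compound 1 tolerates phenylsulfanyl, with a 3.1-fold lower number from compound 1 to compound 3 (0.50 log units; beyond the scatter) on that exchange. Enlarging the group on the sulfur still raises the number, with a 2.3-fold higher number from compound 2 to compound 3 (0.37 log units; beyond the scatter) as phenyl replaces methyl, so compound 2 remains lowest of the three. Nothing available explains the direction or size of this step.

As far as these compounds go, with only methyl and phenyl on the sulfur, it remains open how the number changes across intermediate groups. An ethyl or benzyl group on the sulfur, or an amine on the same ring carbon, could test this further.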